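A Diisopropylcarbamoyl Group on the Shared Core

This account rests on a few compounds, and the source may have more. Where it says the series, first, only, none or still open, it means among the compounds named here.

In a functional assay on SMMC-7721 cells (Homo sapiens) for antiproliferative activity, read by MTT assay, with a stated time of 48 h (a lower number here means a stronger inhibitor, a higher number a weaker inhibitor), compound 1 `CC(C)=CCC[C@]1(C)/C=C/[C@@H](OC(=O)C=C(C)C)[C@](C)(O)/C=C/C(=O)/C(C[Si](C)(C)C(C)(C)C)=C\C1` gives 4000 nM and compound 2 `CO/N=C/C1=C/C[C@](C)(CCC=C(C)C)/C=C/[C@@H](OC(=O)C=C(C)C)[C@](C)(O)/C=C/C1=O` gives 3470 nM. These two numbers lie within the scatter of each other, so compound 2 stands level with compound 1. Compound 3 `CC(C)=CCC[C@]1(C)/C=C/[C@@H](OC(=O)C=C(C)C)[C@](C)(O)/C=C/C(=O)/C(C(=O)N(C(C)C)C(C)C)=C\C1` shares their core and carries a diisopropylcarbamoyl group on the double-bonded ring carbon where compound 2 holds its own group: a group of 9 heavy atoms (7 carbon, 1 nitrogen, 1 oxygen; no ring) in place of a group of 4 heavy atoms (2 carbon, 1 nitrogen, 1 oxygen; no ring), on a double-bonded ring carbon. Within the data shown here, one measured step bears on this change, at the same ring carbon: a 1.2-fold lower number from compound 1 to compound 2 (0.06 log units; within the scatter). That exchange of groups stayed within the scatter, so no step beyond the scatter, in either direction, is expected in this assay. This is thin evidence, since no amide at this carbon has yet been measured. The estimated step, a 1.1-fold higher number from compound 2 to compound 3 (0.04 log units; within the scatter), is expected to be small. Compound 3 is estimated at 3800 nM, with an expected range of 1500 nM to 9500 nM.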

Compound 3, half-maximal inhibitory concentration: 17200 nM
The estimate for compound 3 lay 4.5-fold (0.66 log units) below the measured number; measured number above the stated range.
By their numbers in this assay, from the lowest: compounds 2 and 1 (each within the scatter of the next); then compound 3.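

In this assay this ring carbon proved not to be indifferent to the group it carries: the diisopropylcarbamoyl group brought a 5.0-fold higher number from compound 2 to compound 3 (0.70 log units; beyond the scatter) and a 4.3-fold higher number from compound 1 to compound 3 (0.63 log units; beyond the scatter) even though the earlier exchange at the same carbon had stayed within the scatter. Heavy-atom count does not order these compounds, since compound 1 and compound 2 stand level despite the larger gap in count between their groups, while compound 3 separates from compound 1 with a group close in count to the one it replaces. Nothing available here accounts for this separation.

The compounds shown leave open whether the amide itself or its two isopropyl groups go with the higher number. A dimethylcarbamoyl group, an unsubstituted carboxamide or a carboxylic acid on this carbon would bear on that question.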